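A few compounds are considered here, and "the series" means these few. Any claim that something is new, unique, unknown or untested is made for them only; others in the source may bear on it.

Measured compounds:
Compound 1, `N#CC1=C(N)Oc2c(c3nc4ccccc4nc3c3ccccc23)C12C(=O)N(Cc1cnnn1-c1ccc(F)c(Cl)c1)c1ccccc12`: > 50000 nM
Compound 2, `N#CC1=C(N)Oc2c(N)cc3nc4ccccc4nc3c2C12C(=O)N(Cc1cnnn1-c1ccc(F)cc1)c1ccccc12`: > 50000 nM

Both were tested in an ADME assay on L02 cells (Homo sapiens) for antiproliferative activity, read by MTT assay, with a stated time of 48 h; a higher number here means a weaker inhibitor, a lower number a stronger inhibitor. For compound 1 the result > 50000 nM is a limit of the assay and not a measured number. For compound 2 the result > 50000 nM is likewise a limit and not a number. So compound 2 stands at the limit of this assay, and the one further value shown stands there too: the limit of > 50000 nM in this assay, at which 2 of the 2 values shown sit. Nothing finer can be said about how compound 2 compares with compound 1.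

The compound not yet measured is compound 3, `Cc1ccc(-n2nncc2CN2C(=O)C3(C(C#N)=C(N)Oc4c(N)cc5nc6ccccc6nc5c43)c3ccccc32)cc1C`. It differs from compound 2 in one place: 3,4-dimethylphenyl in place of 4-fluorophenyl on an aromatic nitrogen. Going by the values given here, no pair of measured compounds that differ in a single place is available, so the size of this step cannot be read from a precedent. In this assay the step from compound 2 is expected to be none beyond the usual scatter, in either direction. Compound 3 is therefore expected to give about 70000 nM, within 20000 nM to 200000 nM, and most likely again to be reported only as a limit. The expected step is a step that the limit leaves unreadable from compound 2 to compound 3.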

Compound 3, half-maximal inhibitory concentration: > 50000 nM
Compound 3: no number, only a limit; the forecaster's own chance of this, stated with the estimate: 80%; the middle value lies beyond the limit too.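

Going by these compounds alone, compound 2 and compound 3 both give only a limit and not a number, so no step between them can be read, and the effect of 3,4-dimethylphenyl in place of 4-fluorophenyl stays unknown: the limit of > 50000 nM in this assay, at which 3 of the 3 values shown sit. The compounds shown leave open what actual concentration, if any, would inhibit the growth of these cells.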